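The source may hold more compounds than are shown below. What is called first, only, known or untested is meant among the compounds shown, and "the series" means these compounds.

Three compounds of the series are measured in a functional assay on HCT-116 cells (Homo sapiens) for inhibition, read by sulforhodamine B assay, with a stated time of 48 h, tested at 50 uM; a higher number here means more inhibition of growth at the concentration tested, a lower number less inhibition of growth. Compound 1 `COc1ccccc1/C=C/C(=O)/C=C/c1ccc(OCc2cn(CCCCCOc3cc(=O)oc4ccccc34)nn2)c(OC)c1` gives 33%. Compound 2 `COc1cc(/C=C/C(=O)/C=C/c2ccco2)ccc1OCc1cn(CCOc2cc(=O)oc3ccccc23)nn1` gives 72%. Compound 3 `COc1cc(/C=C/C(=O)/C=C/c2ccco2)ccc1OCc1cn(CCCCCOc2cc(=O)oc3ccccc23)nn1` gives 37%. Compound 2 stands highest of the three, beyond the scatter from both others; the difference between its core and that of compound 3 is not broken down here.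

The change 2-methoxyphenyl in place of furan-2-yl on a double-bonded chain carbon bound to a double-bonded chain carbon produced a number 4 percentage points lower from compound 3 to compound 1 (within the scatter). The same change, (2-methoxyphenyl in place of furan-2-yl on a double-bonded chain carbon bound to a double-bonded chain carbon), leads from compound 2 to the unmeasured compound 4 `COc1ccccc1/C=C/C(=O)/C=C/c1ccc(OCc2cn(CCOc3cc(=O)oc4ccccc34)nn2)c(OC)c1`. Because the earlier step of a number 4 percentage points lower from compound 3 to compound 1 (within the scatter) was within the scatter, compound 4 is expected to show a step of about a number 5 percentage points lower from compound 2 to compound 4 (within the scatter) in this assay. Compound 4 is therefore estimated at 67% in this assay, with a range from 48% to 84%. The two occurrences rest on a single measured pair, so this is tentative.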

Compound 4, percent growth inhibition at one concentration: 70%
Compound 4: the middle estimate sits 3 percentage points below what was measured; the range from low to high includes it.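

In this assay, 2-methoxyphenyl in place of furan-2-yl on a double-bonded chain carbon bound to a double-bonded chain carbon gives a number 2 percentage points lower from compound 2 to compound 4 (within the scatter). Among these compounds, the change behaves alike on both cores, with no step beyond the scatter on either: the same change on two cores in this assay, a number 4 percentage points lower (within the scatter) from compound 3 to compound 1 and a number 2 percentage points lower (within the scatter) from compound 2 to compound 4, 2 percentage points apart, within the scatter of two such steps This covers only two cores at a single tested concentration, so it does not show that the change would stay as small on any other core.

Open, from the compounds shown here alone, is whether other groups in that place, such as thiophen-2-yl or a phenyl bearing a carboxylic acid, would read like these two. Also open, going by these compounds, is how the change reads on a core with a longer chain.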